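The source may hold more compounds than are shown below. What is called first, only, known or untested is meant among the compounds shown, and "the series" means these compounds.

Three compounds share one core, differing only in the aromatic acyl group on the amide nitrogen. Compound 1 `O=C(CCCCC[C@H](NC(=O)c1cc2ccccc2[nH]1)C(=O)NCc1ccccc1)NO` carries the unsubstituted group; in a functional assay on NFF cells (Homo sapiens) for antiproliferative activity (on this read-out higher numbers stand for weaker inhibition and lower numbers for stronger inhibition), compound 1 gives 1260 nM. Compound 2 `O=C(CCCCC[C@H](NC(=O)c1cc2c(Br)cccc2[nH]1)C(=O)NCc1ccccc1)NO` has bromo in place of hydrogen on an aromatic carbon, and in this assay compound 2 gives 1940 nM. Compound 3 `O=C(CCCCC[C@H](NC(=O)c1cc2c(O)cccc2[nH]1)C(=O)NCc1ccccc1)NO` has hydroxy in place of hydrogen on that same aromatic carbon, and in this assay compound 3 gives 2210 nM. Its number is nominally the highest of the three, yet the steps of a 1.8-fold higher number from compound 1 to compound 3 (0.24 log units; within the scatter) and a 1.1-fold higher number from compound 2 to compound 3 (0.06 log units; within the scatter) are both within the scatter, as is a 1.5-fold higher number from compound 1 to compound 2 (0.19 log units; within the scatter).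

Compound 4 `O=C(/C=C/c1c[nH]c2ccccc12)N[C@@H](CCCCCC(=O)NO)C(=O)NCc1ccccc1` alters the acyl group itself: 2-(1H-indol-3-yl)ethenyl in place of 4-hydroxy-1H-indol-2-yl on a carbonyl carbon. Among the compounds with values here, none of the measured steps bears directly on this change; each only swapped a small group on an aromatic carbon, and each stayed within the scatter. With no measured guide for exchanging the whole acyl group, the reasonable expectation is a number close to that of compound 3, held with a wide range. Compound 4 is therefore estimated to give 1800 nM, between 500 nM and 6000 nM, an expected step of a 1.2-fold lower number from compound 3 to compound 4 (0.09 log units; within the scatter).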

Compound 4, half-maximal inhibitory concentration: 10400 nM
Compound 4: middle estimate off by 5.8-fold (0.76 log units), on the low side; the whole stated range lies below it.
By their numbers in this assay, from the lowest: compounds 1, 2 and 3 (each within the scatter of the next); then compound 4.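

Small swaps on an aromatic carbon stayed within the scatter, but replacing the whole acyl group moves the number well past it in this assay: the result is a 4.7-fold higher number from compound 3 to compound 4 (0.67 log units; beyond the scatter) and a 5.4-fold higher number from compound 2 to compound 4 (0.73 log units; beyond the scatter) and also an 8.3-fold higher number from compound 1 to compound 4 (0.92 log units; beyond the scatter) in the same direction. The group on this carbonyl carbon therefore matters more than the small substituents did, and compound 4 is the weakest of the four, since its steps to all three others lie beyond the scatter. No measurement here explains the loss.

The entering 2-(1H-indol-3-yl)ethenyl differs in both its double bond and its point of attachment, and the compounds shown cannot separate these two changes. A plain 1H-indol-3-yl or a saturated 2-(1H-indol-3-yl)ethyl on the same carbonyl carbon would help tell them apart.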